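A few compounds are considered here, and "the series" means these few. Any claim that something is new, unique, unknown or untested is made for them only; others in the source may bear on it.

Three compounds have been measured in an assay on isolated protein for displacement of a labelled ligand from metabotropic glutamate receptor 5 (Homo sapiens), with a stated time of 60 min, tested at 1 uM; a higher number here means more inhibition at the concentration tested (going by the name of the read-out), a lower number less inhibition:

Compound 1 `Cc1ccc2ncc(S(=O)(=O)c3ccc(F)cc3)c(N3CCC(C)CC3)c2c1`, 90%
Compound 2 `Cc1cc(C)cc(S(=O)(=O)c2cnc3cc(F)ccc3c2N2CCC(C)CC2)c1`, 80%
Compound 3 `COc1ccc2ncc(S(=O)(=O)c3cccc(Cl)c3)c(N3CCC(C)CC3)c2c1`, -3%

Compound 2 sits close to compound 1, the two lying within the usual scatter of each other, and far above compound 3, a gap well beyond the scatter. Compound 4 `CC1CCN(c2c(S(=O)(=O)c3ccc(C#N)cc3)cnc3cc(F)ccc23)CC1` has not yet been measured. It differs from compound 2 in one place: 4-cyanophenyl in place of 3,5-dimethylphenyl on a sulfonyl sulfur. Going by the values given here, no measured pair shows this exact change, so the expected step from compound 2 to compound 4 is uncertain; a small drop, not clearly beyond the scatter, is expected, a number 10 percentage points lower from compound 2 to compound 4 (within the scatter), because compound 1 with its 4-fluorophenyl on the same sulfonyl sulfur gives 90%. Compound 4 is therefore estimated at 70%, within a range from 35% to 95%.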

Compound 4, a percentage reported as inhibition, at one concentration (the size of the read-out at that concentration, not a potency): 83%
For compound 4 the middle estimate is 13 percentage points below the measured one, within the range that was stated.
By their numbers in this assay, from the lowest: compound 3; then compounds 2, 4 and 1 (each within the scatter of the next).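

In this assay, replacing 3,5-dimethylphenyl with 4-cyanophenyl on a sulfonyl sulfur gives a number 3 percentage points higher from compound 2 to compound 4 (within the scatter). Going by these compounds alone, this is the first direct one-place comparison at this position, and it shows that an aromatic ring bearing a nitrile and one bearing methyl groups read alike here. Nothing available explains this likeness.

On these data alone, whether an amine or a carboxylic acid on that phenyl ring would read the same remains open. So does the low number of compound 3, which differs from the others in more than one place.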